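A few compounds are considered here, and "the series" means these few. Any claim that something is new, unique, unknown or untested is made for them only; others in the source may bear on it.

In a functional assay on KB cells (Homo sapiens) for cytotoxicity, read by MTT assay (on this read-out higher numbers stand for weaker inhibition and lower numbers for stronger inhibition), compound 1 (`CCn1cc(C(=O)Nc2cccc([N+](=O)[O-])c2)c(=O)c2cc(F)c(N3CCNC(C)C3)c(F)c21`) gives 1700 nM, compound 2 (`CCn1cc(C(=O)Nc2ccc(C)c([N+](=O)[O-])c2)c(=O)c2cc(F)c(N3CCNC(C)C3)c(F)c21`) gives 3900 nM and compound 3 (`CCn1cc(C(=O)Nc2cc([N+](=O)[O-])ccc2F)c(=O)c2cc(F)c(N3CCNC(C)C3)c(F)c21`) gives 3200 nM. Compound 3 falls inside the span of the other two numbers and cannot be told apart from either: the data show a 1.9-fold higher number from compound 1 to compound 3 (0.27 log units; within the scatter) and a 1.2-fold lower number from compound 2 to compound 3 (0.09 log units; within the scatter). For the measured compounds named here, the only step beyond the scatter is a 2.3-fold higher number from compound 1 to compound 2 (0.36 log units; beyond the scatter), and it is modest.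

Compound 4 (`CCn1cc(C(=O)Nc2ccc(C(C)=O)cc2)c(=O)c2cc(F)c(N3CCNC(C)C3)c(F)c21`) is next in this assay. Its difference from compound 3 is 4-acetylphenyl in place of 2-fluoro-5-nitrophenyl on an amide-type nitrogen. Going by the values given here, no measured compound carries the 4-acetylphenyl group, and all three measured compounds keep a nitro group on the ring, so no measured step tests this exchange directly. The closest guide is the set of three steps above, all changes to the ring on the amide-type nitrogen, and all small. On that limited evidence, no step beyond the scatter is expected, and the data set no direction. The expected change is a 1.1-fold lower number from compound 3 to compound 4 (0.03 log units; within the scatter), with a wide margin for a substitution not yet sampled. For compound 4 the estimated value is 3000 nM, with an expected range of 1000 nM to 9000 nM.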

Compound 4, half-maximal inhibitory concentration: 42600 nM
Compound 4: the middle estimate sits 14-fold (1.15 log units) below what was measured; measured number above the stated range.
By their numbers in this assay, from the lowest: compounds 1, 3 and 2 (each within the scatter of the next, the first and the last beyond it); then compound 4.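

Working notes on the ring on the amide-type nitrogen: in this assay, the three nitro-bearing compounds left this place looking nearly flat, but the exchange to 4-acetylphenyl gives large steps against all of them: a 13-fold higher number from compound 3 to compound 4 (1.12 log units; beyond the scatter), an 11-fold higher number from compound 2 to compound 4 (1.04 log units; beyond the scatter) and a 25-fold higher number from compound 1 to compound 4 (1.40 log units; beyond the scatter). All three steps run towards weaker inhibition and each is much larger than any step among the nitro-bearing compounds, so the small methyl and fluoro changes showed only a narrow part of what this place can do to the read-out. Nothing at hand bears on why the 4-acetylphenyl ring behaves so differently from the nitro-bearing rings.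

The exchange removes the nitro group and brings in the acetyl in a single change, so the compounds shown cannot say whether the step follows the loss of the one or the arrival of the other. An unsubstituted phenyl, a 3-acetylphenyl or a 4-nitrophenyl group on the same amide-type nitrogen would separate these two readings, and a 3-aminophenyl group would show whether a ring without nitro can stay near the values of the nitro-bearing compounds.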